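This account rests on a few compounds, and the source may have more. Where it says the series, first, only, none or still open, it means among the compounds named here.

Measured compounds:
compound 1 `CC(=O)OC(C)n1cnc2c(Cl)nc(N)nc21` — in a functional assay (Homo sapiens) for inhibition; on this read-out lower numbers stand for stronger inhibition and higher numbers for weaker inhibition: > 500000 nM, a limit of the assay
compound 2 `CC(=O)OC(C)n1cnc2c(Cl)nc(I)nc21` — in this assay: 14500 nM
compound 3 `CC(=O)OC(C)n1cnc2c(Cl)nc(F)nc21` — in this assay: 93300 nM

Compound 1 is the weakest of the three; its value is only a limit (the limit of > 500000 nM in this assay, at which 1 of the 3 values shown sits), with no number behind it. Compounds 2 and 3 both give numbers. There is an at least 34-fold lower number from compound 1 to compound 2 (1.53 log units; beyond the scatter). There is an at least 5.3-fold lower number from compound 1 to compound 3 (0.72 log units; beyond the scatter). There is also a 6.4-fold higher number from compound 2 to compound 3 (0.81 log units; beyond the scatter).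

Compound 4 `CC(=O)OC(C)n1cnc2c(S)nc(N)nc21` differs from compound 1 by sulfanyl in place of chloro on an aromatic carbon. The measured steps all replace the amino group of compound 1 and keep the chloro, so none of them bears on the chloro position; they show only that large shifts occur in this assay when the amino position is varied. For the chloro position there is no comparison. The expectation therefore rests on compound 1 itself, which sits at the limit (the limit of > 500000 nM in this assay, at which 1 of the 3 values shown sits). Compound 4 is accordingly expected to stay near that limit, with an at least 1.2-fold lower number from compound 1 to compound 4 (0.09 log units; that floor lies within the scatter). The estimate for compound 4 is 400000 nM, with a range from 50000 nM to 3000000 nM, and a fair chance that this assay again reports only a limit.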

Compound 4, half-maximal inhibitory concentration: 25000 nM
Compound 4: the middle estimate sits 16-fold (1.20 log units) above what was measured, outside the stated range (below it).
By their numbers in this assay, from the lowest: compounds 2 and 4 (each within the scatter of the next); then compound 3. At a limit, above all of these: compound 1.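

In this assay, for the compounds shown here, sulfanyl in place of chloro, with the amino group kept, gives an at least 20-fold lower number from compound 1 to compound 4 (1.30 log units; beyond the scatter) and so shows that the chloro position, unchanged in the earlier compounds, can also move the read-out. Large shifts in this series are therefore not confined to the amino position. The size of this step is a floor and not an exact figure, since compound 1 carries only a limit: the limit of > 500000 nM in this assay, at which 1 of the 4 values shown sits.

Sulfanyl is the only group shown against chloro at this position, so a methylthio group, a hydroxyl or an amine would be needed to tell whether the shift follows the sulfur atom or the sulfanyl hydrogen. Also open, from the compounds shown here alone, is whether sulfanyl in place of chloro would act in the same way on compound 2 and compound 3, where iodo and fluoro replace the amino group.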